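Replacing a biaryl tail with a hydroxymethyl group

This account rests on a few compounds, and the source may have more. Where it says the series, first, only, none or still open, it means among the compounds named here.

Measured compounds:
compound 1 `Cc1ccc(-c2ccc(NC3=CC(=O)c4ncncc4C3=O)cc2F)cc1` — 5000 nM
compound 2 `COc1ccc(-c2ccc(NC3=CC(=O)c4ncncc4C3=O)cc2)cc1` — 3500 nM
compound 3 `O=C1C(Nc2cccc(B(O)O)c2)=CC(=O)c2ncncc21` — > 10000 nM

Of the compounds shown here, three share one core and have been tested in a functional assay on BXPC-3 cells (Homo sapiens) for cytotoxicity, read by MTT assay, with a stated time of 72 h; on this read-out lower numbers stand for stronger inhibition and higher numbers for weaker inhibition. Compound 2 gives 3500 nM, the lowest of the two numbers that were reported. Compound 1 gives 5000 nM, which sits within the usual scatter of compound 2, so the two cannot be told apart. For compound 3 the result is only a limit, > 10000 nM, and not a number; this is the limit of > 10000 nM in this assay, at which 1 of the 3 values shown sits.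

The piece follows the step from compound 2 to compound 4 `O=C1C(Nc2ccc(CO)cc2)=CC(=O)c2ncncc21`, which has not yet been tested. The change is hydroxymethyl in place of 4-methoxyphenyl on an aromatic carbon.

Among the measured compounds shown here, no step between measured compounds exists to guide this change. Compound 3, which also carries a small polar group in place of an aryl tail on that ring, reached only a limit, > 10000 nM, and this points toward a step for compound 4 in the direction of a higher number in this assay, beyond the scatter. Compound 4 is therefore expected to give about 8000 nM, within 3000 nM to 20000 nM, a step of a 2.3-fold higher number from compound 2 to compound 4 (0.36 log units; beyond the scatter).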

Compound 4, half-maximal inhibitory concentration: 5700 nM
Beside the measured number, compound 4's estimate is 1.4-fold (0.15 log units) above it, within the range that was stated.
By their numbers in this assay, from the lowest: compounds 2, 1 and 4 (each within the scatter of the next). At a limit, above all of these: compound 3.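

Among the compounds shown here, exchanging 4-methoxyphenyl for hydroxymethyl in this assay gives a 1.6-fold higher number from compound 2 to compound 4 (0.21 log units; within the scatter), the only step between measured compounds at this position. The aromatic carbon para to a large group can therefore carry either a tail of 8 heavy atoms with a six-membered aromatic ring or a hydroxymethyl of 2 heavy atoms with no ring, and this read-out does not tell the two apart, even though hydroxymethyl brings 1 hydrogen-bond donor where 4-methoxyphenyl has none. Compound 3 remains the only compound whose result is a limit and not a number: the limit of > 10000 nM in this assay, at which 1 of the 4 values shown sits.

The compounds shown do not reveal what lies behind this closeness, nor whether any group at this position can move the number beyond the scatter. Going by these compounds, how an amine, a carboxylic acid or a longer chain such as hydroxyethyl on this aromatic carbon would read in this assay stays open, as does whether a methyl ether in place of the hydroxymethyl would read the same.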